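Adding a chloro group to compound 2

The source may hold more compounds than are shown below. What is called first, only, known or untested is meant among the compounds shown, and "the series" means these compounds.

Compound 1 `COc1ccc(/C=C2\S/C(=N\c3ccc(C(C)(C)C)cc3)N(C)C2=O)cc1` in a functional assay on MCF7 cells (Homo sapiens) for antiproliferative activity, read by MTT assay, with a stated time of 72 h (a higher number here means a weaker inhibitor, a lower number a stronger inhibitor), gives > 100000 nM, a limit of the assay.
Compound 2 `COc1ccc(/C=C2\S/C(=N\c3ccccc3)N(C)C2=O)cc1` in this assay gives > 100000 nM, also a limit of the assay.
Compound 3 `COc1ccc(/C=C2/CN(C)/C(=N/c3ccc(OC)cc3)S2)cc1` in this assay gives 8700 nM.

Compound 2 therefore stands at the upper limit of this assay, where no number is read; (the limit of > 100000 nM in this assay, at which 2 of the 3 values shown sit). Among the measured compounds shown here, the one recorded step that touches it, a step that the two limits leave unreadable from compound 1 to compound 2, runs between two limits and its size cannot be read. Compound 3, built on a different core, is the only one of the three with a numeric value, and nothing connects it to compound 2 by a single change.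

Compound 4 `COc1ccc(/C=C2\S/C(=N\c3ccc(Cl)cc3)N(C)C2=O)cc1` differs from compound 2 in one place: chloro in place of hydrogen on an aromatic carbon.

For the measured compounds named here, no measured step speaks to this change. Going by the values given here, both compounds that share the core of compound 2 sit at the limit, so the direction of a step that the two limits leave unreadable from compound 1 to compound 2 cannot be used, and there is no other pair with a change on that aromatic carbon. The expectation for compound 4 therefore rests on compound 2 alone: the step of an at least 1.2-fold lower number from compound 2 to compound 4 (0.09 log units; that floor lies within the scatter) is expected to be small, with a fair chance that compound 4 again returns only a limit. Compound 4 is estimated at 80000 nM, between 20000 nM and 300000 nM.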

Compound 4, half-maximal inhibitory concentration: 39300 nM
The estimate for compound 4 lay 2.0-fold (0.31 log units) above the measured number; low and high end bracket the measured number.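

Among the compounds shown here, compound 4 is the only compound on the shared core to give a number in this assay, 39300 nM, which shows that a change on this aromatic carbon, para to a large group, can bring the series within reading range: chloro in place of hydrogen gives an at least 2.5-fold lower number from compound 2 to compound 4 (0.40 log units; beyond the scatter). Chloro in place of tert-butyl on that carbon gives an at least 2.5-fold lower number from compound 1 to compound 4 (0.40 log units; beyond the scatter), so among the three groups shown there, only chloro yields a number. Both steps are floors rather than sizes, because each starts from a compound that sits at a limit: the limit of > 100000 nM in this assay, at which 2 of the 4 values shown sit.

On these data alone, the step between compound 1 and compound 2 still cannot be read, so hydrogen and tert-butyl cannot be ranked against each other, and the full size of the gain from chloro remains unknown. Whether the gain is particular to chloro also stays open, since the compounds shown do not tell how a bromo, a trifluoromethyl or an amine on that aromatic carbon would compare.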